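Same Aryl Swap, Tested on a Longer Linker

A few compounds are considered here, and "the series" means these few. Any claim that something is new, unique, unknown or untested is made for them only; others in the source may bear on it.

Measured compounds and their values in a functional assay on PC-12 cells (Rattus norvegicus) for cytotoxicity, read by MTT assay, with stated times of 3 h and 2 h, tested at 1 uM; on this read-out lower numbers stand for a weaker effect and higher numbers for a stronger effect at the one concentration tested:
compound 1, `O=C(CCCCC1CCSS1)NCc1cn(CCCCOc2ccc3cc(-c4ccc(Br)cc4)c(=O)oc3c2)nn1`: 37.4%
compound 2, `O=C(CCCCC1CCSS1)NCc1cn(CCCCOc2ccc3cc(-c4ccc(Cl)c(Cl)c4)c(=O)oc3c2)nn1`: 49.3%
compound 3, `O=C(CCCCC1CCSS1)NCc1cn(CCCCCOc2ccc3cc(-c4ccc(Br)cc4)c(=O)oc3c2)nn1`: 43.7%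

Compound 1 and compound 2 share a core and differ only in one place: 3,4-dichlorophenyl in place of 4-bromophenyl on an aromatic carbon. In this assay this change gave a number 11.9 percentage points higher from compound 1 to compound 2 (beyond the scatter). Compound 3 carries the same 4-bromophenyl as compound 1, but its core is not the same; the difference between the two cores is not broken down here. Compound 3 and compound 2 give numbers within the scatter of each other, as do compound 3 and compound 1.

The unmeasured compound 4, `O=C(CCCCC1CCSS1)NCc1cn(CCCCCOc2ccc3cc(-c4ccc(Cl)c(Cl)c4)c(=O)oc3c2)nn1`, stands to compound 3 as compound 2 stands to compound 1: 3,4-dichlorophenyl in place of 4-bromophenyl on an aromatic carbon. The place lines are identical, so this is the same change. Because the change from compound 1 to compound 2 gave a number 11.9 percentage points higher from compound 1 to compound 2 (beyond the scatter), a step of similar size is expected from compound 3 to compound 4, namely a number 11.3 percentage points higher from compound 3 to compound 4 (beyond the scatter). Compound 4 is therefore estimated to give 55% in this assay, with a likely range from 41% to 69%.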

Compound 4, a percentage reported as activity, at one concentration (the size of the read-out at that concentration, not a potency): 50.6%
Estimate against measurement, compound 4: 4.4 percentage points above; the range from low to high includes it.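

In this assay the swap of 4-bromophenyl for 3,4-dichlorophenyl on the core of compound 3 gave a number 6.9 percentage points higher from compound 3 to compound 4 (within the scatter) and so, on this core alone, cannot be told apart from the ordinary spread of repeated measurements. Set beside the same swap on the core of compound 1, the two steps do not differ: the same change on two cores in this assay, a number 11.9 percentage points higher (beyond the scatter) from compound 1 to compound 2 and a number 6.9 percentage points higher (within the scatter) from compound 3 to compound 4, 5 percentage points apart, within the scatter of two such steps

The change can therefore be said to carry over between these two cores with a step of comparable size, but this does not show a clear gain on the second core, and two cores cannot establish a rule for the whole series. The read-out also comes from a single concentration, so it says nothing about potency.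

The compounds shown leave open how other aryl groups, such as 4-methoxyphenyl or 4-fluorophenyl, would behave at this position. They also leave open whether the swap would give a similar step with a still longer chain in the linker.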